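Trading an acid for an amine on the aryl tail

The source may report more compounds than this note shows. Statements on the series, on what has been measured and on what is new or still open speak of the compounds shown alone.

Compound 1, `O=C(CCCCCc1ccc(CO)cc1)N1CCOC1=O`, gives 190 nM in an assay on HEK293 cells for inhibition of N-acylethanolamine-hydrolyzing acid amidase (Rattus norvegicus), read by LC-MS, with a stated time of 30 min; a higher number here means a weaker inhibitor, a lower number a stronger inhibitor.
Compound 2, `O=C(O)c1ccc(CCCCCC(=O)N2CCOC2=O)cc1`, gives > 20000 nM in this assay.

For compound 2 the number reported is a limit of this assay and not a measured value. Within this pair compound 2 therefore sits at the weak end: the only step measured, an at least 100-fold higher number from compound 1 to compound 2 (2.02 log units; beyond the scatter), runs from compound 1 to it, and this is documented as the limit of > 20000 nM in this assay, at which 1 of the 2 values shown sits.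

Compound 3, `Nc1ccc(CCCCCC(=O)N2CCOC2=O)cc1`, has not yet been measured. It differs from compound 2 by amino in place of carboxy on an aromatic carbon, that is, an amino group now occupies the aromatic carbon para to the large group where the carboxy stood. Going by the values given here, the one measured step bears directly on this position: exchanging the hydroxymethyl of compound 1 for carboxy gave an at least 100-fold higher number from compound 1 to compound 2 (2.02 log units; beyond the scatter). Removing the carboxy again, in favour of a small neutral group, is expected to undo much of that loss, so a large step downward in this assay is expected, an at least 33-fold lower number from compound 2 to compound 3 (1.52 log units; beyond the scatter). Compound 3 is therefore estimated at 600 nM, with a range from 100 nM to 6000 nM.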

Compound 3, half-maximal inhibitory concentration: 15700 nM
Compound 3: the middle estimate sits 26-fold (1.42 log units) below what was measured, and the stated range ends below it.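

The loss of strength at this aromatic carbon is not tied to the carboxy alone, since a group with no acid function also falls well short of the hydroxymethyl of compound 1 in this assay: amino in place of hydroxymethyl gives an 83-fold higher number from compound 1 to compound 3 (1.92 log units; beyond the scatter). Exchanging carboxy for amino gives an at least 1.2-fold lower number from compound 2 to compound 3 (0.10 log units; that floor lies within the scatter), so the result shows no real gain from that exchange, although the true size of the step could be larger than this floor. The reading for compound 2 is a limit of the assay and not a number, which leaves the step open at its upper end: the limit of > 20000 nM in this assay, at which 1 of the 3 values shown sits.

Going by these compounds alone, what the hydroxymethyl contributes remains open, since only three groups at this carbon can be compared here, and a methyl, a methoxymethyl or an aminomethyl group in the same place would help to show whether the oxygen, the extra carbon or both matter. From the compounds shown here alone, it is also open whether a hydroxyl group on the ring, or a longer chain leading to the hydroxymethyl, would match or improve on compound 1.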